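Adding a methyl to the phenyl of compound 3

This account rests on a few compounds, and the source may have more. Where it says the series, first, only, none or still open, it means among the compounds named here.

Compound 3 `COc1cc2c(Oc3ccc(NC(=O)c4nccc(-c5ccccc5)n4)cc3F)ccnc2cc1OCCCN1CCCCC1` has no single number in a functional assay on U-87MG ATCC cells (Homo sapiens) for cytotoxicity, read by MTT assay, with a stated time of 72 h; a higher number here means a weaker inhibitor, a lower number a stronger inhibitor; its entry there reads "not determined" (no result reported). The same holds for compound 1 `COc1ccc(-c2ccnc(C(=O)Nc3ccc(Oc4ccnc5cc(OCCCN6CCCC6)c(OC)cc45)c(F)c3)c2)cc1`, whose entry in this assay also reads "not determined" (no result reported). The only numerical anchor in the set is compound 2 `COc1cc2c(Oc3ccc(NC(=O)c4cc(-c5ccccc5)ccn4)cc3F)ccnc2cc1OCCCN1CCCCC1`, for which this assay gives 790 nM. Among the measured compounds shown here, no step between two measured compounds is available, so the position of compound 3 on the scale cannot be placed from its own data, and the expectation for the next compound rests on the one measured value and on the nature of the change.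

Compound 4 `COc1cc2c(Oc3ccc(NC(=O)c4nccc(-c5ccc(C)cc5)n4)cc3F)ccnc2cc1OCCCN1CCCCC1` differs from compound 3 in one place: methyl in place of hydrogen on an aromatic carbon. Methyl in place of hydrogen on an aromatic carbon is a small change, and with no measured step of this kind anywhere in the series the expected effect in this assay is none beyond the scatter; a direction cannot be called from these data. Compound 4 is therefore estimated at 800 nM in this assay, within a range of 200 nM to 4000 nM, taking as the nearest reference compound 2 with 790 nM. There is some chance that compound 4, like compound 3, returns no number.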

Compound 4, half-maximal inhibitory concentration: 1140 nM
Compound 4: the middle estimate sits 1.4-fold (0.15 log units) below what was measured, and the stated range covers the measured number.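

Compound 3 has no single number in this assay while compound 4 gives 1140 nM and no step can be read between them. No supporting data bear on this result. The compounds shown leave open what the change from phenyl to 4-methylphenyl does to the half-maximal inhibitory concentration in this assay.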